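Nitro in Place of Chloro: Expected Toxicity of Compound 3

A few compounds are considered here, and "the series" means these few. Any claim that something is new, unique, unknown or untested is made for them only; others in the source may bear on it.

Measured compounds:
- compound 1, `Cn1c(-c2cccc(Cl)c2)cnc1NC(=O)c1ccc(F)cc1`: > 50000 nM in a toxicity assay on THP-1 cells (Homo sapiens) for inhibition; on this read-out lower numbers stand for higher toxicity in this test and higher numbers for lower toxicity in this test
- compound 2, `Cn1c(-c2ccc(C#N)cc2)cnc1NC(=O)c1ccc(F)cc1`: > 50000 nM in this assay

Compound 1 stands only at a limit: in this assay compound 1 gives > 50000 nM, which is a limit of the assay rather than a number. Compound 2 likewise gives > 50000 nM in this assay, again a limit. Among the compounds with values here, the one measured step, a step that the two limits leave unreadable from compound 1 to compound 2, cannot be read in size because the limit of > 50000 nM in this assay, at which 2 of the 2 values shown sit, covers both compounds.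

Compound 3 (`Cn1c(-c2cccc([N+](=O)[O-])c2)cnc1NC(=O)c1ccc(F)cc1`) differs from compound 1 by nitro in place of chloro on an aromatic carbon. Within the data shown here, no measured step bears directly on this change, and the single step available gives no readable size. With nothing to point either way, compound 3 is expected to remain at the same limit, an expected step that the limit leaves unreadable from compound 1 to compound 3. The estimate for compound 3 in this assay is 80000 nM, with an expected range from 40000 nM to 300000 nM.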

Compound 3, half-maximal cytotoxic concentration: > 50000 nM
Compound 3: no number, only a limit (the forecaster's own chance of this, stated with the estimate: 85%); the middle value does not contradict the limit.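

No new step can be read, since compound 3 also stands at a limit, so the change from compound 1 to compound 3 has no size: the limit of > 50000 nM in this assay, at which 3 of the 3 values shown sit.

The compounds shown leave open how toxic any of the three actually is, and whether any change on the shared core would give a readable number in this assay.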